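The source may hold more compounds than are shown below. What is called first, only, known or untested is meant among the compounds shown, and "the series" means these compounds.

Measured in a functional assay on A549 cells (Homo sapiens) for cytotoxicity, read by MTT assay, with a stated time of 48 h; a higher number here means a weaker inhibitor, a lower number a stronger inhibitor:
- compound 1 `CCOC(=O)[C@@]1(C(=O)Nc2ccccc2)C[C@@H]1c1cc(OC)c(OC)c(OC)c1`: > 100000 nM (a limit)
- compound 2 `CCOC(=O)C1(C(=O)Nc2ccc(F)cc2)CC1c1cc(OC)c(OC)c(OC)c1`: 22400 nM; 28000 nM (2 entries)
- compound 3 `CCOC(=O)[C@@]1(C(=O)Nc2ccccc2Cl)C[C@@H]1c1cc(OC)c(OC)c(OC)c1`: 29000 nM

Within the data shown here, compound 3, at 29000 nM, is the only compound here with one plain number. Compound 2 has several entries (the several entries of compound 2 in this assay, 22400 nM; 28000 nM (2 entries)). Compound 1 sits at a limit (the limit of > 100000 nM in this assay, at which 1 of the 3 values shown sits).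

Compound 4 `CCOC(=O)[C@]1(C(=O)Nc2ccccc2Cl)C[C@H]1c1cc(OC)c(OC)c(OC)c1` is the mirror image of compound 3: the two compounds have the same atoms and bonds and differ only in configuration as drawn: 2 of 2 stereo elements differ (all stereocentres are inverted: mirror images); a stereocentre at a saturated ring carbon is drawn S in compound 3 and R in compound 4; a stereocentre at a saturated ring carbon is drawn R in compound 3 and S in compound 4. Among the measured compounds shown here, the one measured step, an at least 3.4-fold lower number from compound 1 to compound 3 (0.53 log units; beyond the scatter), places chloro on an aromatic carbon without changing the configuration as drawn, so it bears only indirectly. For the measured compounds named here, no measured pair shows the effect of inversion, so no step beyond the scatter can be predicted in either direction, though the uncertainty is wide. The expected step is a 1.0-fold higher number from compound 3 to compound 4 (0.01 log units; within the scatter). For compound 4 the estimated value is 30000 nM, with an expected range of 10000 nM to 100000 nM.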

Compound 4, half-maximal inhibitory concentration: 13400 nM
Compound 4: middle estimate off by 2.2-fold (0.35 log units), on the high side; measured number inside the range.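

In this assay, the step of a 2.2-fold lower number from compound 3 to compound 4 (0.34 log units; beyond the scatter) is the first measured effect of configuration among these compounds, and it lies beyond the scatter. With the chloro group held constant, this step can be assigned to inversion of both stereocentres, because nothing else changes: the fact that compounds 3 and 4 differ only in the configuration as drawn. The earlier step showed only what chloro does within one configuration as drawn.

The compounds shown leave open whether the same mirror-image difference would appear without chloro. They also leave open whether it would persist with an amine or a carboxylic acid on the aromatic ring, or with a longer chain in place of the ethyl ester.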